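Cytotoxicity notes on a pyrazolopyridine amide series

This account rests on a few compounds, and the source may have more. Where it says the series, first, only, none or still open, it means among the compounds named here.

Measured compounds in this set:
compound 1 `CC(C)n1ncc2c(C(=O)Nc3cccnc3)cc(-c3ccsc3)nc21`: 37000 nM
compound 2 `CC(C)n1ncc2c(C(=O)Nc3c(F)cccc3F)cc(-c3cccs3)nc21`: a limit of the assay, > 200000 nM
compound 3 `CC(C)n1ncc2c(C(=O)Nc3ccccc3F)cc(-c3ccccc3)nc21`: a limit of the assay, > 200000 nM

For the measured compounds named here, in an ADME assay on LLC-MK2 cells (Macaca mulatta) for cytotoxicity, read by spectrophotometry and crystal violet staining, with a stated time of 4 days (on this read-out lower numbers stand for higher toxicity in this test and higher numbers for lower toxicity in this test), compound 1 gives 37000 nM and is the only compound of the three with a number rather than a limit. Compound 2 reports only > 200000 nM, a limit of the assay. Compound 3 also reports only a limit, > 200000 nM. Compound 2 therefore stands at the limit of > 200000 nM in this assay, at which 2 of the 3 values shown sit, so its true value is not pinned down.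

Compound 4 `CC(C)n1ncc2c(C(=O)Nc3ccc(F)cn3)cc(-c3cccs3)nc21` is the next compound, not yet measured. It differs from compound 2 by 5-fluoropyridin-2-yl in place of 2,6-difluorophenyl on an amide-type nitrogen. Going by the values given here, no measured pair in this set shows the same change, so there is no step to lean on. Among the compounds with values here, compound 1, the one compound carrying a pyridinyl on the amide nitrogen, gives 37000 nM. The two compounds with fluorinated phenyl groups there, compound 2 and compound 3, each report only a limit of the assay; this contrast rests on a single compound and may be coincidence. The expected step from compound 2 to compound 4 is an at least 1.6-fold lower number from compound 2 to compound 4 (0.22 log units; that floor lies within the scatter), toward lower numbers, i.e. somewhat higher toxicity in this assay, though a result at the limit remains quite possible. Compound 4 is estimated at 120000 nM, with a range from 40000 nM to 200000 nM.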

Compound 4, half-maximal cytotoxic concentration: > 200000 nM
Compound 4: no number, only a limit (the forecaster's own chance of this, stated with the estimate: 50%); middle value at least 1.6-fold (0.22 log units) from the limit.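

Compound 4 reports > 200000 nM, a limit of the assay. For the compounds shown here, compound 2 also stands only at a limit, so no step from it to compound 4 can be read in this assay. The compounds shown leave open whether 5-fluoropyridin-2-yl in place of 2,6-difluorophenyl changes this read-out at all.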